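The source may hold more compounds than are shown below. What is called first, only, known or untested is meant among the compounds shown, and "the series" means these compounds.

Of the compounds shown here, two with the same shared core have been tested so far, each carrying a benzyl group that bears a chloromethyl group. Compound 1 `Nc1nc(Cl)c2ncn(Cc3ccccc3CCl)c2n1` and compound 2 `Nc1nc(Cl)c2ncn(Cc3ccc(CCl)cc3)c2n1` differ only in where that chloromethyl group sits on the benzyl ring. In a functional assay on NCI/ADR-RES cells (Homo sapiens) for cytotoxicity, read by sulforhodamine B assay, with a stated time of 48 h (on this read-out higher numbers stand for weaker inhibition of growth and lower numbers for stronger inhibition of growth), compound 1 gives 4470 nM. In this assay compound 2 gives 3310 nM. The gap between these two numbers lies within the scatter of repeated measurements, so compound 1 stands level with compound 2 on what has been measured.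

Compound 3 `ClCc1ccccc1Cn1cnc2c(Cl)nc(Cl)nc21` keeps the benzyl group and chloromethyl group of compound 1 and changes the core itself: chloro in place of amino on an aromatic carbon. Among the measured compounds shown here, no pair among the measured compounds shows what such a change does in this assay, so any expectation rests on the structural change alone. The step from compound 1 to compound 3 is expected to be small, with a slight lean toward stronger growth inhibition, as a 1.5-fold lower number from compound 1 to compound 3 (0.17 log units; within the scatter). On that basis compound 3 is estimated to give 3000 nM in this assay, within a range from 1000 nM to 9000 nM.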

Compound 3, concentration for 50% growth inhibition: 1510 nM
Compound 3: middle estimate off by 2.0-fold (0.30 log units), on the high side; measured number inside the range.
By their numbers in this assay, from the lowest: compound 3; then compounds 2 and 1 (each within the scatter of the next).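

Swapping the amino group for chloro on this aromatic carbon, which sits between two ring nitrogen atoms, gives the first step among these compounds that lies beyond the scatter in this assay: the change is a 3.0-fold lower number from compound 1 to compound 3 (0.47 log units; beyond the scatter), a modest step toward stronger growth inhibition. The earlier pair varied only where the chloromethyl group sits on the benzyl ring and stayed level, so this result adds that a change on the core itself can move the number, and that the amino group at this position is not needed for growth inhibition in these cells. No measurement at hand gives a reason for this step.

From the compounds shown here alone, it remains open whether the stronger inhibition comes from the chloro group itself or simply from losing the amino group, a question that a hydrogen, a methyl group or a methoxy group on the same carbon could help to settle. Going by these compounds, it is also open whether the same swap gives a similar step when the chloromethyl group sits where it does in compound 2.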